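Taking the bromoethenyl carbonyl group off compound 2

The source may report more compounds than this note shows. Statements on the series, on what has been measured and on what is new or still open speak of the compounds shown alone.

In a functional assay on MOLT-4 cells (Homo sapiens) for antiproliferative activity, with a stated time of 48 h (on this read-out higher numbers stand for weaker inhibition and lower numbers for stronger inhibition), compound 1 (`C=C(Br)C(=O)Nc1ccc(C(=O)/C=C/c2ccc(OC)cc2)cc1`) gives 610 nM and compound 2 (`C=C(Br)C(=O)Nc1ccc(C(=O)/C=C/c2ccccc2OC)cc1`) gives 240 nM as the lower of the two numbers. Compound 3 (`COc1ccccc1/C=C/C(=O)c1ccc(N)cc1`) differs from compound 2 by one change, hydrogen in place of (1-bromoethenyl)carbonyl on a nitrogen on an aromatic ring. Within the data shown here, the one measured step is a 2.5-fold lower number from compound 1 to compound 2 (0.41 log units; beyond the scatter) and puts 2-methoxyphenyl in place of 4-methoxyphenyl, so it bears only indirectly on this change. Among the measured compounds shown here, no measured compound lacks the departing group, and the data give no direct size for its loss. Losing that whole group is expected to weigh more than this modest step, so the estimate is a 25-fold higher number from compound 2 to compound 3 (1.40 log units; beyond the scatter) toward weaker inhibition. Compound 3 is estimated at 6000 nM with an expected range from 1500 nM to 25000 nM in this read-out.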

Compound 3, half-maximal inhibitory concentration: 8300 nM
The estimate for compound 3 lay 1.4-fold (0.14 log units) below the measured number; the measured number falls inside the stated range.
By their numbers in this assay, from the lowest: compound 2; then compound 1; then compound 3.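

In this assay, replacing (1-bromoethenyl)carbonyl with hydrogen on the nitrogen gives a 35-fold higher number from compound 2 to compound 3 (1.54 log units; beyond the scatter), a large step toward weaker inhibition. The earlier compounds showed only the modest effect of moving the methoxy group, a 2.5-fold lower number from compound 1 to compound 2 (0.41 log units; beyond the scatter), whereas this result shows that the group on the nitrogen accounts for much of the potency of compound 2, although compound 3 still gives a measurable 8300 nM. No evidence is available on the reason for this loss.

The compounds shown leave open which part of the departing group matters, the bromine, the double bond or the carbonyl. From the compounds shown here alone, an acetyl, propenoyl or 2-bromopropanoyl group on the same nitrogen would separate these parts, and it remains open how much of the step each would recover.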